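This account rests on a few compounds, and the source may have more. Where it says the series, first, only, none or still open, it means among the compounds named here.

Measured so far:
compound 1 `CC[C@H](C)[C@@H](NC(=O)Cn1cc(C2=C(c3c[nH]c4ccccc34)C(=O)N(C)C2=O)c2ccccc21)C(=O)OC` — > 100000 nM
compound 2 `COC(=O)CCNC(=O)Cn1cc(C2=C(c3c[nH]c4ccccc34)C(=O)N(C)C2=O)c2ccccc21` — 47800 nM

In a functional assay on MCF7 cells (Homo sapiens) for cytotoxicity, read by MTT assay, with a stated time of 24 h (on this read-out higher numbers stand for weaker inhibition and lower numbers for stronger inhibition), compound 1 gives only a limit, (the limit of > 100000 nM in this assay, at which 1 of the 2 values shown sits), and no number. Compound 2 gives 47800 nM in this assay. Among the measured compounds shown here, the one measured step is an at least 2.0-fold lower number from compound 1 to compound 2 (0.32 log units; beyond the scatter); it exchanges the whole amino-acid ester portion at the amide-type nitrogen and is known only from the limit side, so its true size is open.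

Compound 3 `COC(=O)C[C@@H](NC(=O)Cn1cc(C2=C(c3c[nH]c4ccccc34)C(=O)N(C)C2=O)c2ccccc21)C(=O)OC` keeps the core of compound 1 and its amide; the difference is (methoxycarbonyl)methyl in place of sec-butyl on a saturated chain carbon bound to an amide-type nitrogen and a carbonyl carbon. This is a narrower change than the measured step: the stereocentre and the methoxycarbonyl on that carbon stay, only the branched alkyl gives way to a second ester-bearing chain. For the measured compounds named here, the step from compound 1 to compound 2 is the only guide, and it points toward a lower number once the sec-butyl is gone, with no measured anchor for compound 1 itself. A modest lowering, of the order of that step, is therefore expected, an at least 1.8-fold lower number from compound 1 to compound 3 (0.25 log units; that floor lies within the scatter), though a further limit cannot be ruled out. Compound 3 is estimated at 55000 nM in this assay, within 20000 nM to 150000 nM.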

Compound 3, half-maximal inhibitory concentration: 25800 nM
For compound 3 the middle estimate is 2.1-fold (0.33 log units) above the measured one; measured number inside the range.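

In this assay, (methoxycarbonyl)methyl in place of sec-butyl on a saturated chain carbon bound to an amide-type nitrogen and a carbonyl carbon gives an at least 3.8-fold lower number from compound 1 to compound 3 (0.58 log units; beyond the scatter), so this narrower exchange, which keeps the stereocentre and the methoxycarbonyl on that carbon, is already enough to move the read-out beyond the scatter. From the compounds shown here alone, compound 1 stands only as a limit, and the true size of that step stays open because of it: the limit of > 100000 nM in this assay, at which 1 of the 3 values shown sits. Methoxycarbonyl in place of hydrogen on a saturated chain carbon bound to an amide-type nitrogen and a saturated chain carbon gives a 1.9-fold lower number from compound 2 to compound 3 (0.27 log units; within the scatter), which lies within the scatter, so compound 2 and compound 3 cannot be told apart here and the second methoxycarbonyl has no readable effect at this position.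

The compounds shown leave open how a carboxylic acid in place of either methoxycarbonyl would read in this assay. Also open, going by these compounds, is whether a longer chain carrying the ester, or an amine on the saturated chain carbon, would stay level with compound 2 and compound 3 or move away from them.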